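Sulfonyl substituent variation on the shared piperazine-linked core

This account rests on a few compounds, and the source may have more. Where it says the series, first, only, none or still open, it means among the compounds named here.

Measured compounds:
compound 1, `CC(C)OC(=O)N1CCC(COc2ccc(N3CCN(C(=O)N(C)C)CC3)nc2)CC1`, > 10000 nM
compound 2, `CCS(=O)(=O)N1CCN(c2ccc(OCC3CCN(C(=O)OC(C)C)CC3)cn2)CC1`, 1300 nM
compound 3, `CC(C)OC(=O)N1CCC(COc2ccc(N3CCN(S(=O)(=O)c4cccs4)CC3)nc2)CC1`, 1800 nM

In a functional assay on CHO-K1 cells for agonist activity at Glucose-dependent insulinotropic receptor (Homo sapiens), read by a luciferase reporter, with a stated time of 5 h (a lower number here means that less compound is needed, a higher number that more compound is needed for the effect), compound 1 reaches only a limit, > 10000 nM, and no number (the limit of > 10000 nM in this assay, at which 1 of the 3 values shown sits). Compound 2 gives the lowest number among the two numbers shown; compound 3 sits a 1.4-fold higher number from compound 2 to compound 3 (0.14 log units; within the scatter), so the two cannot be ordered. Replacing dimethylcarbamoyl by a sulfonyl group gave an at least 7.6-fold lower number from compound 1 to compound 2 (0.88 log units; beyond the scatter) and an at least 5.5-fold lower number from compound 1 to compound 3 (0.74 log units; beyond the scatter).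

Compound 4, `CCN(CC)S(=O)(=O)N1CCN(c2ccc(OCC3CCN(C(=O)OC(C)C)CC3)cn2)CC1`, keeps the sulfonyl of compound 2 but carries diethylamino in place of ethyl on a sulfonyl sulfur. Among the measured compounds shown here, the one measured step that exchanges the group on the sulfonyl sulfur, from ethyl to thiophen-2-yl, stayed within the scatter, so for compound 4 in this assay no step beyond the scatter is expected, a 1.2-fold higher number from compound 2 to compound 4 (0.06 log units; within the scatter). Compound 4 is therefore estimated at 1500 nM, between 600 nM and 4000 nM.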

Compound 4, half-maximal effective concentration: 1200 nM
Compound 4: middle estimate off by 1.3-fold (0.10 log units), on the high side; the range from low to high includes it.
By their numbers in this assay, from the lowest: compounds 4, 2 and 3 (each within the scatter of the next). At a limit, above all of these: compound 1.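

With a nitrogen-bound group on the sulfonyl sulfur, this assay still shows no separation from the carbon-bound groups: a 1.1-fold lower number from compound 2 to compound 4 (0.03 log units; within the scatter) and a 1.5-fold lower number from compound 3 to compound 4 (0.18 log units; within the scatter). Three different groups at this place, ethyl, thiophen-2-yl and diethylamino, therefore sit within the scatter of one another. With diethylsulfamoyl in place of dimethylcarbamoyl, the number falls clearly, an at least 8.3-fold lower number from compound 1 to compound 4 (0.92 log units; beyond the scatter), though this step starts from a limit: the limit of > 10000 nM in this assay, at which 1 of the 4 values shown sits.

Going by these compounds, whether any group on the sulfonyl sulfur moves the number beyond the scatter remains open. A phenyl ring, a longer alkyl chain or a chain ending in a carboxylic acid would test this.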